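From (isopropylcarbonyl)oxy to methoxy on the shared core

This account rests on a few compounds, and the source may have more. Where it says the series, first, only, none or still open, it means among the compounds named here.

In a functional assay on A549 cells (Homo sapiens) for cytotoxicity, with a stated time of 48 h (a higher number here means a weaker inhibitor, a lower number a stronger inhibitor), compound 1 `C[S+]([O-])/C=C/c1cc(=O)c2cc(C#N)ccc2o1` gives > 10000 nM, which is a limit of the assay and not a number. Compound 2 `CCC(=O)Oc1ccc2oc(/C=C/[S+](C)[O-])cc(=O)c2c1` gives 2400 nM, and compound 3 `CC(C)C(=O)Oc1ccc2oc(/C=C/[S+](C)[O-])cc(=O)c2c1` gives 2400 nM, so compound 3 stands level with compound 2.

Compound 4 `COc1ccc2oc(/C=C/[S+](C)[O-])cc(=O)c2c1` is still unmeasured in this assay. It differs from compound 3 by methyl in place of isopropylcarbonyl on an oxygen on an aromatic ring, so that (isopropylcarbonyl)oxy becomes methoxy: methyl in place of isopropylcarbonyl on an oxygen on an aromatic ring.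

Within the data shown here, no measured step makes this exact change, but three bear on it. Two concern the group on the aromatic carbon, and they show an at least 4.1-fold lower number from compound 1 to compound 2 (0.61 log units; beyond the scatter) and an at least 4.1-fold lower number from compound 1 to compound 3 (0.61 log units; beyond the scatter). The third concerns the acyl chain, and it shows no change at the digits printed from compound 2 to compound 3 (within the scatter). Thus the chain change left the value unmoved, while the group with a nitrile in compound 1 sits at the limit. Methoxy keeps the oxygen on the ring but loses the carbonyl, so it falls outside what these steps cover.

A modest move towards a higher number is therefore expected, as a 2.1-fold higher number from compound 3 to compound 4 (0.32 log units; beyond the scatter), though a step within the scatter remains possible. The estimate for compound 4 is 5000 nM, with an expected range of 2000 nM to 12000 nM.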

Compound 4, half-maximal inhibitory concentration: 1600 nM
The estimate for compound 4 lay 3.1-fold (0.49 log units) above the measured number, and the stated range ends above it.
By their numbers in this assay, from the lowest: compounds 4, 2 and 3 (each within the scatter of the next). At a limit, above all of these: compound 1.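

In this assay, the carbonyl of the ester turns out not to be required at this position, on an oxygen on an aromatic ring: a 1.5-fold lower number from compound 3 to compound 4 (0.18 log units; within the scatter), and a 1.5-fold lower number from compound 2 to compound 4 (0.18 log units; within the scatter). The two esters alone varied only the acyl chain, whereas methoxy removes the whole acyl group and leaves a single methyl on the oxygen, and all three values still lie within the scatter of one another. The step away from the nitrile, an at least 6.2-fold lower number from compound 1 to compound 4 (0.79 log units; beyond the scatter), points the same way as the steps from the nitrile to the two esters, an at least 4.1-fold lower number from compound 1 to compound 2 (0.61 log units; beyond the scatter) and an at least 4.1-fold lower number from compound 1 to compound 3 (0.61 log units; beyond the scatter), but each rests on a limit and not a number, so it gives a bound only: the limit of > 10000 nM in this assay, at which 1 of the 4 values shown sits.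

What remains open is whether the oxygen on the aromatic carbon itself matters, since a free hydroxy group, an amine or a plain hydrogen at that place is not among the compounds shown. It is also open how far this tolerance extends, as a longer alkoxy chain such as butoxy or a benzoyl ester lies outside the compounds shown.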